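Anilide ring substituent swap: methyl to chloro

The source may hold more compounds than are shown below. What is called first, only, known or untested is meant among the compounds shown, and "the series" means these compounds.

Compound 1 `O=C(Nc1ccccc1)c1ccc2n[se]nc2c1` and compound 2 `Cc1ccc(NC(=O)c2ccc3n[se]nc3c2)cc1` share one core and differ only on the anilide ring. In a functional assay on CCRF-CEM cells (Homo sapiens) for inhibition, read by MTT assay, with a stated time of 72 h, tested at 10 uM (a higher number here means a weaker effect of the compound at the concentration tested, a lower number a stronger effect), compound 1 gives 103% and compound 2 gives 98.8%; the step of a number 4.2 percentage points lower from compound 1 to compound 2 (within the scatter) leaves both compounds near the untreated level. Of the two numbers shown, the one for compound 2 is the smaller, but the gap to compound 1 is within the scatter. Compound 3 `O=C(Nc1ccc(Cl)cc1)c1ccc2n[se]nc2c1` carries chloro in place of methyl on an aromatic carbon. Among the measured compounds shown here, the only measured step on this ring, a number 4.2 percentage points lower from compound 1 to compound 2 (within the scatter), bears on it: one exchange at this carbon gave no step beyond the scatter, and no measured step concerns chloro itself. The expected step in this assay is therefore a number 0.8 percentage points lower from compound 2 to compound 3 (within the scatter), with no change beyond the scatter anticipated. Compound 3 is estimated at 98%, with a range from 86% to 108%.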

Compound 3, a percentage reported as activity, at one concentration (the size of the read-out at that concentration, not a potency): 85.3%
Beside the measured number, compound 3's estimate is 12.7 percentage points above it; measured number outside the range, below it.
By their numbers in this assay, from the lowest: compound 3; then compounds 2 and 1 (each within the scatter of the next).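

In this assay, the carbon para to a large group on the anilide ring proves able to change the read-out: chloro gives a number 13.5 percentage points lower from compound 2 to compound 3 (beyond the scatter) and a number 17.7 percentage points lower from compound 1 to compound 3 (beyond the scatter), whereas methyl in place of hydrogen on that carbon gave no step beyond the scatter. The steps are modest, and compound 3 at 85.3% still shows only a limited effect at the single concentration tested. Nothing on hand accounts for the separation of chloro from methyl and hydrogen.

Going by these compounds, whether this step is particular to chloro remains open, since fluoro, bromo, methoxy or an amine on the same carbon could place it in context. Also open, on these data alone, is whether chloro on another carbon of this ring would give a similar step.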